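A few compounds are considered here, and "the series" means these few. Any claim that something is new, unique, unknown or untested is made for them only; others in the source may bear on it.

Measured in an ADME assay on THP-1 cells (Homo sapiens) for cytotoxicity, read by flow cytometry and propidium iodide staining, with a stated time of 72 h; a lower number here means a stronger inhibitor, a higher number a weaker inhibitor:
Compound 1, `COc1ccccc1-c1cc(=O)c2cc(NC(C)=O)ccc2o1`, gives 50000 nM.
Compound 2, `COc1ccccc1-c1oc2ccc(NC(C)=O)cc2c(=O)c1OC`, gives 108000 nM.
Compound 3, `COc1c(-c2ccccc2)oc2ccc(N)cc2c1=O`, gives 74000 nM.

From compound 1 to compound 2 the change is methoxy in place of hydrogen on an aromatic carbon, and it produced a 2.2-fold higher number from compound 1 to compound 2 (0.33 log units; beyond the scatter). Compound 3 carries a different core; how the core of compound 3 differs from the core of compound 1 is not broken down here. In this assay compound 3 stands within the scatter of both compound 1 and compound 2, so no order among the three can be stated from these numbers alone.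

Compound 4, `COc1cccc(-c2oc3ccc(N)cc3c(=O)c2OC)c1`, has not yet been measured. It differs from compound 3 by methoxy in place of hydrogen on an aromatic carbon. Among the measured compounds shown here, this is the same kind of change as the one from compound 1 to compound 2, but not the same: there the methoxy entered on a six-membered aromatic ring with one oxygen, part of a fused system, ortho to a 2-methoxyphenyl group; here it enters on a six-membered aromatic ring of carbon only, meta to a large group. Resting on compound 1 to compound 2 giving a 2.2-fold higher number from compound 1 to compound 2 (0.33 log units; beyond the scatter), the step is expected to be a 1.5-fold higher number from compound 3 to compound 4 (0.17 log units; within the scatter). Compound 4 is therefore estimated at 110000 nM, with a range from 50000 nM to 250000 nM.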

Compound 4, half-maximal inhibitory concentration: 37000 nM
The estimate for compound 4 lay 3.0-fold (0.47 log units) above the measured number, outside the stated range (below it).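

In this assay, methoxy in place of hydrogen on an aromatic carbon did not behave as one transferable step, and the two cases differ by more than the scatter allows: the same change on two cores in this assay, a 2.2-fold higher number (0.33 log units; beyond the scatter) from compound 1 to compound 2 and a 2.0-fold lower number (0.30 log units; within the scatter) from compound 3 to compound 4, 4.3-fold (0.64 log units) apart, beyond the scatter of two such steps. Taken alone, the new case, a 2.0-fold lower number from compound 3 to compound 4 (0.30 log units; within the scatter), is no firm change, so the result shows that the rise seen on the core of compound 1 was not repeated, not that methoxy lowers the number on the core of compound 3. The two cases also differ in where the methoxy enters, and with one pair on each core the data cannot separate the effect of the core from that of the place, nor predict the step on any further core.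

The compounds shown leave open whether a hydroxyl, a fluorine or a longer chain such as ethoxy at this place on the six-membered aromatic ring of carbon only would give a similar result. They also leave open whether the step depends on having an amine rather than an acetamide on the shared scaffold.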